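From 5-chloro-1H-indol-3-yl to 2-bromophenyl

The source may hold more compounds than are shown below. What is called first, only, known or untested is meant among the compounds shown, and "the series" means these compounds.

In a functional assay on DU-145 cells (Homo sapiens) for inhibition, read by trypan blue exclusion, with a stated time of 96 h (a lower number here means a stronger inhibitor of growth, a higher number a weaker inhibitor of growth), compound 3 `Cc1ccc(CS/C(=C/c2c[nH]c3ccc(Cl)cc23)C(=O)c2ccc(Cl)cc2)cc1` gives 1000 nM, level with compound 2 `Cc1ccc(CS/C(=C/c2c[nH]c3ccc(Br)cc23)C(=O)c2ccc(Cl)cc2)cc1` at 1000 nM. These two share the lowest number of the three, and compound 1 `Cc1ccc(CS/C(=C/c2ccccc2F)C(=O)c2ccc(Cl)cc2)cc1` gives 10000 nM. Compound 4 `Cc1ccc(CS/C(=C/c2ccccc2Br)C(=O)c2ccc(Cl)cc2)cc1` differs from compound 3 by 2-bromophenyl in place of 5-chloro-1H-indol-3-yl on a double-bonded chain carbon bound to a double-bonded chain carbon, with 2-bromophenyl in place of 5-chloro-1H-indol-3-yl on a double-bonded chain carbon bound to a double-bonded chain carbon. The nearest evidence is a 10-fold lower number from compound 1 to compound 3 (1.00 log units; beyond the scatter), on replacing 2-fluorophenyl with 5-chloro-1H-indol-3-yl, matched by a 10-fold lower number from compound 1 to compound 2 (1.00 log units; beyond the scatter) with 5-bromo-1H-indol-3-yl. Exchanging the halogen on the indolyl group gave no change at the digits printed from compound 2 to compound 3 (within the scatter). Leaving the indolyl group should therefore undo most of that modest step. The expected change is a 7.0-fold higher number from compound 3 to compound 4 (0.85 log units; beyond the scatter). For compound 4 the estimated value is 7000 nM, with a range of 2500 nM to 20000 nM.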

Compound 4, concentration for 50% growth inhibition: 10000 nM
The estimate for compound 4 lay 1.4-fold (0.15 log units) below the measured number; low and high end bracket the measured number.
By their numbers in this assay, from the lowest: compounds 2 and 3 (each within the scatter of the next); then compounds 1 and 4 (each within the scatter of the next).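

In this assay, the loss on leaving the indolyl group appears with both halogens, as a 10-fold higher number from compound 3 to compound 4 (1.00 log units; beyond the scatter) and a 10-fold higher number from compound 2 to compound 4 (1.00 log units; beyond the scatter), so the exchange of indolyl for phenyl carries the difference at this place. Among the compounds shown here, the halogen exchange on the phenyl group, no change at the digits printed from compound 1 to compound 4 (within the scatter), matches the one on the indolyl group, and halogen identity separates neither pair. No measurement here explains why the indolyl compounds give the lower numbers. From the compounds shown here alone, whether that gain rests on the hydrogen-bond donor or on the second ring stays open; a 1-methylindol-3-yl or a naphthyl group at this place would separate the two.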